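The compounds below may be only part of what the source reports. "The series", "measured", "known", "first", "only" and "open" are said of these compounds alone.

Compound 3 `O=C1O[C@H]([C@@H](O)Cn2cc(CNS(=O)(=O)c3ccc(F)cc3)nn2)C(OCc2ccccc2)=C1OCc1ccccc1` gives 18300 nM in a functional assay on HepG2 cells (Homo sapiens) for antiproliferative activity, read by MTT assay, with a stated time of 72 h (a higher number here means a weaker inhibitor, a lower number a stronger inhibitor), and stands second highest of the three numbers, nearest to compound 1 `Cc1ccc(S(=O)(=O)NCc2cn(C[C@H](O)[C@H]3OC(=O)C(OCc4ccccc4)=C3OCc3ccccc3)nn2)cc1`, which gives 24900 nM, and furthest from compound 2 `O=C1O[C@H]([C@@H](O)Cn2cc(-c3cc(F)cc(F)c3)nn2)C(OCc2ccccc2)=C1OCc1ccccc1`, which gives 11600 nM. Compound 4 `COc1ccc(-c2cn(C[C@H](O)[C@H]3OC(=O)C(OCc4ccccc4)=C3OCc3ccccc3)nn2)cc1` differs from compound 3 by 4-methoxyphenyl in place of (((4-fluorophenyl)sulfonyl)amino)methyl on an aromatic carbon. Among the measured compounds shown here, two measured steps bear on this kind of exchange: a 2.1-fold lower number from compound 1 to compound 2 (0.33 log units; beyond the scatter) and, in the reverse sense, a 1.6-fold higher number from compound 2 to compound 3 (0.20 log units; within the scatter). Both point the same way, the first beyond the scatter and the second not, so a modest lowering of the number is expected for compound 4, a 1.8-fold lower number from compound 3 to compound 4 (0.26 log units; within the scatter). Compound 4 is therefore estimated at 10000 nM, with a range from 4000 nM to 25000 nM.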

Compound 4, half-maximal inhibitory concentration: 46400 nM
For compound 4 the middle estimate is 4.6-fold (0.67 log units) below the measured one, outside the stated range (above it).
By their numbers in this assay, from the lowest: compounds 2, 3, 1 and 4 (each within the scatter of the next, the first and the last beyond it).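

In this assay an aryl group on this aromatic carbon does not by itself lower the number: 4-methoxyphenyl in place of 3,5-difluorophenyl gives a 4.0-fold higher number from compound 2 to compound 4 (0.60 log units; beyond the scatter), so what the phenyl ring carries counts here. 4-Methoxyphenyl in place of (((4-fluorophenyl)sulfonyl)amino)methyl gives a 2.5-fold higher number from compound 3 to compound 4 (0.40 log units; beyond the scatter), while in place of (((4-methylphenyl)sulfonyl)amino)methyl it gives a 1.9-fold higher number from compound 1 to compound 4 (0.27 log units; within the scatter). Nothing measured here explains these differences. The compounds shown leave open how an amine or a carboxylic acid on the phenyl ring, in place of methoxy, would behave.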